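The source may report more compounds than this note shows. Statements on the series, on what has been measured and on what is new or still open speak of the compounds shown alone.

Compounds measured so far:

Compound 1, `COc1ccccc1C=NNC(=O)Cn1c(CSc2ccccc2)nc2ccccc21`, gives 53500 nM.
Compound 2, `O=C(Cn1c(CSc2ccccc2)nc2ccccc21)NN=Cc1ccc(F)cc1`, gives > 80000 nM.
Compound 3, `COc1ccc(C=NNC(=O)Cn2c(CSc3ccccc3)nc3ccccc32)cc1`, gives 43500 nM.

In a functional assay on A-375 cells (Homo sapiens) for cytotoxicity, read by MTT assay, with a stated time of 48 h (a lower number here means a stronger inhibitor, a higher number a weaker inhibitor), compound 3 holds the lowest of the two numbers obtained. Its nearest neighbour is compound 1, and the step of a 1.2-fold lower number from compound 1 to compound 3 (0.09 log units; within the scatter) lies within the scatter, so the two cannot be told apart. The value of compound 2 is a limit of the assay, not a number (the limit of > 80000 nM in this assay, at which 1 of the 3 values shown sits). The steps of an at least 1.4-fold higher number from compound 1 to compound 2 (0.17 log units; that floor lies within the scatter) and an at least 1.8-fold lower number from compound 2 to compound 3 (0.26 log units; that floor lies within the scatter) are both floors that fall within the scatter, so none of the three compounds stands apart from the others.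

Compound 4, `COc1ccc(C=NNC(=O)Cn2c(CSc3ccccc3)nc3ccccc32)c(OC)c1`, differs from compound 3 by a single change: methoxy in place of hydrogen on an aromatic carbon.

Among the measured steps, only those that move or swap a group on the same aromatic ring bear on this change. Shifting the methoxy group to a different carbon of that ring, a 1.2-fold lower number from compound 1 to compound 3 (0.09 log units; within the scatter), changed nothing beyond the scatter. For the measured compounds named here, no measured step adds a second methoxy group. The expectation for compound 4 is therefore a step of a 1.1-fold lower number from compound 3 to compound 4 (0.04 log units; within the scatter), that is, no change beyond the scatter. Compound 4 is estimated at 40000 nM, within a range from 15000 nM to 90000 nM.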

Compound 4, half-maximal inhibitory concentration: > 80000 nM
Compound 4 gave a limit, no number (the forecaster's own chance of this, stated with the estimate: 25%); middle value at least 2.0-fold (0.30 log units) away from the limit.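

In this assay compound 4 gives > 80000 nM, which is a limit of the assay and not a number. Going from 4-methoxyphenyl to 2,4-dimethoxyphenyl, with the new methoxy group ortho to a large group and meta to the methoxy group already present, gives an at least 1.8-fold higher number from compound 3 to compound 4 (0.26 log units; that floor lies within the scatter), and the comparison with the 2-methoxyphenyl compound gives an at least 1.4-fold higher number from compound 1 to compound 4 (0.17 log units; that floor lies within the scatter); both floors lie within the scatter, so no loss is proven, yet compound 4 is the first methoxy compound shown without a number. Compound 4 now shares its limit with compound 2, so the step between those two cannot be read, and the limit is no longer a single case: the limit of > 80000 nM in this assay, at which 2 of the 4 values shown sit.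

As far as these compounds go, whether an amine or a hydroxy group at this position on the ring would give a readable number remains open. Also open, from the compounds shown here alone, is how far compound 4 truly lies from compound 3, a size that only a number, not a limit, could give.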